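Swapping Bromo for Chloro on Two Related Cores

This account rests on a few compounds, and the source may have more. Where it says the series, first, only, none or still open, it means among the compounds named here.

Compound 1, `COC(=O)[C@@]1(C)CC[C@@H]2C3=C1CC[C@@H](C)[C@]3(C)C[C@@H]1c3cc(Br)ccc3N[C@H]21`, gives 34000 nM in a functional assay on HBL-100 cells (Homo sapiens) for inhibition, read by sulforhodamine B assay, with a stated time of 48 h; on this read-out lower numbers stand for stronger inhibition of growth and higher numbers for weaker inhibition of growth.
Compound 2, `COC(=O)[C@@]1(C)CC[C@@H]2C3=C1CC[C@@H](C)[C@]3(C)C[C@@H]1c3cc(Cl)ccc3N[C@H]21`, gives 28000 nM in this assay.
Compound 3, `COC(=O)[C@@]1(C)CC[C@@H]2C3=C1CC[C@@H](C)[C@]3(C)Cc1c2[nH]c2c(Br)cccc12`, gives 26000 nM in this assay.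

All three measured compounds sit close together. The change from compound 1 to compound 2 is chloro in place of bromo on an aromatic carbon, and it produced a 1.2-fold lower number from compound 1 to compound 2 (0.08 log units; within the scatter), so the two halogens behave alike on that core. Compound 3 carries a different core; the difference between the two cores is not broken down here. Its value lies within the scatter of both compound 1 and compound 2, so no order among the three can be claimed.

Compound 4, `COC(=O)[C@@]1(C)CC[C@@H]2C3=C1CC[C@@H](C)[C@]3(C)Cc1c2[nH]c2c(Cl)cccc12`, has not yet been measured. It differs from compound 3 by chloro in place of bromo on an aromatic carbon. Going by the values given here, this is the same kind of change as the one from compound 1 to compound 2, but not the same: in compound 1 the exchanged atom sits meta to a fused ring and para to a fused ring, whereas in compound 3 it sits ortho to a fused ring and meta to a fused ring. Because the earlier exchange gave a 1.2-fold lower number from compound 1 to compound 2 (0.08 log units; within the scatter), a step of similar size, a 1.1-fold lower number from compound 3 to compound 4 (0.03 log units; within the scatter), is expected here. In this assay compound 4 is therefore estimated at 24000 nM, with a range from 12000 nM to 48000 nM, resting on the value of compound 3, 26000 nM, and on the small effect of the same exchange on the other core.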

Compound 4, concentration for 50% growth inhibition: 16000 nM
The estimate for compound 4 lay 1.5-fold (0.18 log units) above the measured number; the measured number falls inside the stated range.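

In this assay, putting chloro in place of bromo on the core of compound 3 gave a 1.6-fold lower number from compound 3 to compound 4 (0.21 log units; within the scatter), so this step, like the earlier one, is no larger than the differences expected between repeated measurements. Set side by side, the two steps do not differ, and the exchange carries over from one core to the other without any visible change in its effect: the same change on two cores in this assay, a 1.2-fold lower number (0.08 log units; within the scatter) from compound 1 to compound 2 and a 1.6-fold lower number (0.21 log units; within the scatter) from compound 3 to compound 4, 1.3-fold (0.13 log units) apart, within the scatter of two such steps This does not show that chloro and bromo are interchangeable throughout the series, as the evidence comes from only two pairs on two cores in a single cell line, and the halogen sits in a different place on each core, so any effect of core cannot be separated from any effect of place.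

The compounds shown carry only bromo or chloro on the aromatic ring, which leaves open whether a hydrogen, a methoxy group or an amine on that carbon would give a number clearly apart from these. They also leave open what a carboxylic acid or an amide in place of the methyl ester would do to growth inhibition on either core.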